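Removing a methoxy from the aryl group of a pyrazolopyridine

The source may hold more compounds than are shown below. What is called first, only, known or untested is meant among the compounds shown, and "the series" means these compounds.

In an assay for inhibition of MAP kinase-interacting serine/threonine-protein kinase 1 (Homo sapiens), read by scintillation counting, radiometric assay and 33P incorporation, with a stated time of 60 min, in the presence of a further agent that is not named here (a higher number here means a weaker inhibitor, a lower number a stronger inhibitor), compound 2 `COc1cccc(-c2cc(-c3ccccc3)c3c(N)n[nH]c3n2)c1` gives 4200 nM, the higher of the two numbers, while compound 1 `Nc1n[nH]c2nc(-c3ccccc3)cc(-c3ccc(F)cc3)c12` gives 1300 nM in this assay. Compound 3 `Nc1n[nH]c2nc(-c3ccccc3)cc(-c3ccccc3)c12` is compound 2 with hydrogen in place of methoxy on an aromatic carbon. Nothing here isolates what the methoxy contributes, so compound 3 is expected to land near compound 2, with a modest step of a 1.7-fold lower number from compound 2 to compound 3 (0.23 log units; within the scatter) toward a lower number that may lie within the scatter. In this assay compound 3 is estimated at 2500 nM, with a range from 800 nM to 8000 nM.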

Compound 3, half-maximal inhibitory concentration: 690 nM
For compound 3 the middle estimate is 3.6-fold (0.56 log units) above the measured one; measured number outside the range, below it.
By their numbers in this assay, from the lowest: compounds 3 and 1 (each within the scatter of the next); then compound 2.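

In this assay, taking the methoxy off the 3-methoxyphenyl group gives a 6.1-fold lower number from compound 2 to compound 3 (0.78 log units; beyond the scatter), so at this place, meta to a large group, the methoxy costs rather than stays neutral. Hydrogen in place of fluoro gives a 1.9-fold lower number from compound 1 to compound 3 (0.28 log units; within the scatter), which leaves those two compounds indistinguishable. Nothing available explains the methoxy step.

Among these compounds, whether the step belongs to methoxy alone stays open, since only this one group has been compared with hydrogen at this place. A hydroxy or an amine there could fall near either compound 2 or compound 3.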